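A few compounds are considered here, and "the series" means these few. Any claim that something is new, unique, unknown or untested is made for them only; others in the source may bear on it.

In a functional assay on a cell-free system (Platelet, plasma, Oryctolagus cuniculus) for inhibition, with a stated time of 5 min (a lower number here means a stronger inhibitor, a higher number a weaker inhibitor), compound 1 `COC(=O)c1ccc(OCc2nc(C)c(C)nc2C)c(OC)c1` gives > 2000000 nM as its reading, which is a limit of the assay and not a number. Two other compounds do give numbers: compound 2 `Cc1nc(C)c(COc2ccccc2C(=O)O)nc1C` reads 400000 nM and compound 3 `Cc1nc(C)c(CNC(=O)CN2CCCC2=O)nc1C` reads 1200000 nM in this assay as well.

Compound 4 `C=CCc1ccc(OCc2nc(C)c(C)nc2C)c(OC)c1` keeps the core of compound 1 but has allyl in place of methoxycarbonyl on an aromatic carbon, meta to a methoxy group and para to a large group (allyl in place of methoxycarbonyl on an aromatic carbon). Within the data shown here, no measured pair isolates this change. Among the measured compounds shown here, the only numbers to go on are compound 2 at 400000 nM and compound 3 at 1200000 nM, so a moderate step towards stronger inhibition is expected. Another limit reading is still possible for compound 4. The estimate amounts to an expected at least 2.8-fold lower number from compound 1 to compound 4 (0.45 log units; beyond the scatter) in this assay on these grounds. Compound 4 is estimated at 700000 nM with an expected range of 200000 nM to 2000000 nM in this assay when it is measured.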

Compound 4, half-maximal inhibitory concentration: > 2000000 nM
Compound 4 ended at the assay's limit (the forecaster's own chance of this, stated with the estimate: 30%); middle value at least 2.8-fold (0.45 log units) from the limit.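

No step can be read between compound 1 and compound 4, as both readings are limits of the assay and not numbers: the limit of > 2000000 nM in this assay, at which 2 of the 4 values shown sit.

The compounds shown leave open whether allyl in place of methoxycarbonyl on an aromatic carbon changes inhibition at all, and in which direction.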